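Compound 2 and Its Mirror Image

The source may hold more compounds than are shown below. What is called first, only, known or untested is meant among the compounds shown, and "the series" means these compounds.

In a toxicity assay on MT4 cells (Homo sapiens) for cytotoxicity, read by MTT assay (on this read-out higher numbers stand for lower toxicity in this test and lower numbers for higher toxicity in this test), compound 1 (`O=c1ccn([C@@H]2C=C[C@@]3(CO)C[C@@H]23)c(=O)[nH]1`) gives > 100 ug/mL as a limit, not a number. Compound 2 (`Cc1cn([C@@H]2C=C[C@@]3(CO)C[C@@H]23)c(=O)[nH]c1=O`) gives > 100 ug/mL as a limit too. Compound 2 therefore has no exact position (the limit of > 100 ug/mL in this assay, at which 2 of the 2 values shown sit). Compound 3 (`Cc1cn([C@H]2C=C[C@]3(CO)C[C@H]23)c(=O)[nH]c1=O`) has the same atoms and bonds as compound 2 (the two compounds have the same atoms and bonds and differ only in configuration as drawn: 3 of 3 stereo elements differ (all stereocentres are inverted: mirror images); a stereocentre at a saturated ring carbon is drawn R in compound 2 and S in compound 3; a stereocentre at a saturated ring carbon is drawn S in compound 2 and R in compound 3; a stereocentre at a saturated ring carbon is drawn R in compound 2 and S in compound 3). Among the compounds with values here, the one measured step (a step that the two limits leave unreadable from compound 1 to compound 2) is a different change with no readable size, so it gives no ground to expect a shift. In this assay the expected step (a number no higher from compound 2 to compound 3 (the limit leaves the size open)) is therefore none beyond the scatter. For compound 3 the estimated value is 100 ug/mL (expected range 40 ug/mL to 150 ug/mL) and a limit is the likeliest report.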

Compound 3, half-maximal cytotoxic concentration: 8.56 ug/mL
Estimate against measurement, compound 3: 12-fold (1.07 log units) above; measured number below the stated range.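

In this assay the switch to the mirror image gives an at least 11-fold lower number from compound 2 to compound 3 (1.06 log units; beyond the scatter), and a lower number here stands for higher toxicity. Within the data shown here, this is the first step with a readable size, and it shows that the arrangement of the atoms in space matters in this test even when the atoms themselves stay the same. The structures offer only one source for the shift: the fact that compounds 2 and 3 differ only in the configuration as drawn.

From the compounds shown here alone, whether the mirror image of compound 1 would shift in the same way remains open. So does the effect of an amine or a carboxylic acid on either mirror-image form.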